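The compounds below may be only part of what the source reports. "The series", "measured", "known", "first", "only" and "open" are said of these compounds alone.

Of the compounds shown here, three share a quinone-bearing core and have been tested for their effect on cultured cells. Compound 1 `CC(C)(CNC(=O)c1ccc2ccccc2c1O)CC1=C(O)C(=O)c2ccccc2C1=O` is the parent of interest here. Going by the values given here, two relatives, compound 2 `COC1=C(CC(C)(C)CNC(=O)c2ccccc2)C(=O)c2ccccc2C1=O` and compound 3 `COC1=C(CC(C)(C)CNC(=O)c2ccccc2OC)C(=O)c2ccccc2C1=O`, carry a different core; how that core differs from the one in compound 1 is not broken down here.

In an ADME assay on Vero cells (Chlorocebus sabaeus) for cytotoxicity, read by fluorescence, with a stated time of 4 days (on this read-out lower numbers stand for stronger inhibition and higher numbers for weaker inhibition), compound 1 gives 93700 nM, the highest of the three numbers. Compound 2 gives 12300 nM, and compound 3 gives 27300 nM. Compound 2 and compound 3 differ in one place only (methoxy in place of hydrogen on an aromatic carbon), and that change brought a 2.2-fold higher number from compound 2 to compound 3 (0.35 log units; beyond the scatter), a modest shift toward weaker cell toxicity.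

Compound 4 `COc1cc(C(=O)NCC(C)(C)CC2=C(O)C(=O)c3ccccc3C2=O)c(O)c2ccccc12` is not yet measured. It arises from compound 1 by the same kind of change (methoxy in place of hydrogen on an aromatic carbon), but the surroundings are not the same: in compound 3 the new group sits ortho to a large group, whereas in compound 4 it sits ortho and meta to a fused ring, meta to a large group and para to a hydroxy group. Among the compounds with values here, with only one earlier example of this kind of change, and that one in different surroundings, the expectation rests mainly on the direction seen from compound 2 to compound 3 and on the already high number of compound 1. The step expected from compound 1 to compound 4 is a 1.6-fold higher number from compound 1 to compound 4 (0.20 log units; within the scatter), set beside the earlier 2.2-fold higher number from compound 2 to compound 3 (0.35 log units; beyond the scatter). Compound 4 is therefore estimated at 150000 nM, with a likely range from 60000 nM to 400000 nM, and some chance that this assay reports only a limit.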

Compound 4, half-maximal inhibitory concentration: 15800 nM
Compound 4: middle estimate off by 9.5-fold (0.98 log units), on the high side, and the stated range ends above it.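

In this assay, putting a methoxy in place of hydrogen on an aromatic carbon gave a 5.9-fold lower number from compound 1 to compound 4 (0.77 log units; beyond the scatter), so the number fell here, whereas it rose in the earlier example. Going by these compounds alone, the two steps therefore run in opposite directions, and the gap between them is larger than repeated measurements would explain, which shows that the effect of this change did not carry over from one core to the other: the same change on two cores in this assay, a 2.2-fold higher number (0.35 log units; beyond the scatter) from compound 2 to compound 3 and a 5.9-fold lower number (0.77 log units; beyond the scatter) from compound 1 to compound 4, 13-fold (1.12 log units) apart, beyond the scatter of two such steps This does not show why the direction reversed, since only two pairs are available and they differ both in the core and in what surrounds the new group, which in compound 4 is ortho to a fused ring and para to a hydroxy group.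

The compounds shown leave open which of these differences matters, a question that a compound joining the core of compound 1 to the amide side of compound 2 could help to answer, with and without the methoxy. Also open, as far as these compounds go, is whether an ethoxy group or an amine in the same place on compound 1 would lower the number as the methoxy does.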